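The source may hold more compounds than are shown below. What is called first, only, known or untested is meant among the compounds shown, and "the series" means these compounds.

Two dihydropyridine esters measured so far share one core and differ only in the side chain on a saturated chain carbon bound to a double-bonded ring carbon. Compound 1 `CCCCC1=C(C(=O)OCC)C(c2cccc([N+](=O)[O-])c2)C(C(=O)OCC)=C(C)N1` carries a propyl there and in a functional assay on HEK293 cells for antagonist activity at Voltage-dependent L-type calcium channel subunit alpha-1D (Rattus norvegicus), read by FLIPR (a lower number here means a stronger inhibitor, a higher number a weaker inhibitor), compound 1 gives 20 nM. Compound 2 `CCOC(=O)C1=C(C)NC(CO)=C(C(=O)OCC)C1c1cccc([N+](=O)[O-])c1` carries a hydroxy in that place instead, and in this assay compound 2 gives 45 nM. Compound 2 thus stands at the higher of the two numbers, the step being a 2.3-fold higher number from compound 1 to compound 2 (0.35 log units; beyond the scatter).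

Compound 3 `CCOC(=O)C1=C(C)NC(CCl)=C(C(=O)OCC)C1c1cccc([N+](=O)[O-])c1` differs from compound 2 by chloro in place of hydroxy on a saturated chain carbon bound to a double-bonded ring carbon, the same difference cut one bond further out reading hydroxymethyl to chloromethyl. Among the compounds with values here, only the step of a 2.3-fold higher number from compound 1 to compound 2 (0.35 log units; beyond the scatter) bears on this change, and it shows that swapping the group at this place moves the number only modestly. A chloro is neither of the groups seen there, so the direction is open; a step of similar modest size, or none beyond the scatter, is the expectation. For compound 3 the estimate in this assay is 30 nM, within 12 nM to 80 nM, which would mean an expected step of a 1.5-fold lower number from compound 2 to compound 3 (0.18 log units; within the scatter).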

Compound 3, half-maximal inhibitory concentration: 53 nM
Beside the measured number, compound 3's estimate is 1.8-fold (0.25 log units) below it, within the range that was stated.
By their numbers in this assay, from the lowest: compound 1; then compounds 2 and 3 (each within the scatter of the next).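

In this assay the step from hydroxy to chloro on a saturated chain carbon bound to a double-bonded ring carbon is too small to separate the two compounds (a 1.2-fold higher number from compound 2 to compound 3 (0.07 log units; within the scatter)), even though hydroxy counts one hydrogen-bond donor and one hydrogen-bond acceptor and chloro counts neither. The propyl group, by contrast, now stands apart from chloro as well as from hydroxy (a 2.7-fold higher number from compound 1 to compound 3 (0.42 log units; beyond the scatter)), which makes compound 1 the strongest inhibitor of these three, though only by a modest margin. Nothing measured here explains either result, so the reason for this pattern stays unknown.

From the compounds shown here alone, with only propyl, hydroxy and chloro to compare, it remains open whether a longer chain at this place would give a still lower number than propyl does, or whether the trend would stop there. An amine or a carboxylic acid on the same carbon could also show whether this position tolerates a much wider range of groups than these three, or whether the numbers would move far more sharply.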